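A few compounds are considered here, and "the series" means these few. Any claim that something is new, unique, unknown or untested is made for them only; others in the source may bear on it.

Compound 1 `O=C(NS(=O)(=O)c1ccc(F)cc1)c1ccc(Nc2nc(NC3(c4ccc(Cl)cc4)CC3)nc(OCC(F)(F)F)n2)cc1`: 100%
Compound 2 `CC(C)(C)NC(=O)NCCS(=O)(=O)NC(=O)c1ccc(Nc2nc(NC3(c4ccc(Cl)cc4)CC3)nc(OCC(F)(F)F)n2)cc1`: 96%

In an ADME assay on microsomes from liver (Homo sapiens) for metabolic stability, with a stated time of 10 min (a higher number here means that more of the compound is left, a lower number that less of the compound is left), compound 1 gives 100% and compound 2 gives 96%. Going by the values given here, compound 2 has the lower of the two numbers, but the only measured step, a number 4 percentage points lower from compound 1 to compound 2 (within the scatter), lies within the scatter, so the two compounds show the same outcome. Compound 3 `CC(C)(C)OC(=O)NCCS(=O)(=O)NC(=O)c1ccc(Nc2nc(NC3(c4ccc(Cl)cc4)CC3)nc(OCC(F)(F)F)n2)cc1` differs from compound 2 by tert-butoxy in place of (tert-butyl)amino on a carbonyl carbon. Among the compounds with values here, the one measured step changed a different part of the molecule, so no measured step bears directly on this change. Since compound 2 gives 96%, compound 3 is expected to remain high, with an estimated 92% (range 78% to 100%), a step of a number 4 percentage points lower from compound 2 to compound 3 (within the scatter).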

Compound 3, percent of the compound remaining: 92%
For compound 3 middle estimate and measured number coincide at the digits printed, within the range that was stated.
By their numbers in this assay, from the lowest: compounds 3, 2 and 1 (each within the scatter of the next).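

Exchanging (tert-butyl)amino for tert-butoxy on a carbonyl carbon removes the hydrogen-bond donor counted on the leaving group, yet this assay shows a number 4 percentage points lower from compound 2 to compound 3 (within the scatter) and thus no readable difference at this position. 2-((tert-Butoxycarbonyl)amino)ethyl in place of 4-fluorophenyl on a sulfonyl sulfur likewise gives a number 8 percentage points lower from compound 1 to compound 3 (within the scatter) and no readable difference. No measurement here explains these outcomes. From the compounds shown here alone, whether a free amine, a carboxylic acid or a longer chain at this position would leave the outcome unchanged stays open.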